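The source may hold more compounds than are shown below. What is called first, only, known or untested is meant among the compounds shown, and "the series" means these compounds.

Of the compounds shown here, three of this shared core have been measured in a functional assay on DU-145 cells (Homo sapiens) for cytotoxicity, read by sulforhodamine B assay, with a stated time of 48 h; a lower number here means a stronger inhibitor, a higher number a weaker inhibitor. Compound 1 `COc1ccc2c(c1)c(/C=N/O)cn2Cc1cn([C@@H]2O[C@H](COC(C)=O)[C@@H](OC(C)=O)[C@H](OC(C)=O)[C@H]2OC(C)=O)nn1` gives 88400 nM. Compound 2 `CC(=O)OC[C@H]1O[C@@H](n2cc(CN3C(=O)/C(=C\c4ccccc4)c4ccccc43)nn2)[C@H](OC(C)=O)[C@@H](OC(C)=O)[C@@H]1OC(C)=O` gives 24100 nM, and compound 3 `CC(=O)OC[C@H]1O[C@@H](n2cc(CN3C(=O)/C(=C/c4ccccc4)c4ccccc43)nn2)[C@H](OC(C)=O)[C@@H](OC(C)=O)[C@@H]1OC(C)=O` gives 22800 nM. Among the three numbers, compound 3 carries the lowest; compound 2 lies within the usual scatter of it, while compound 1 sits beyond that scatter. For the measured compounds named here, the only measured step between neighbours, a 1.1-fold lower number from compound 2 to compound 3 (0.02 log units; within the scatter), rests on the fact that compounds 2 and 3 differ only in the configuration as drawn: the two compounds share every atom and bond and differ only in the drawn geometry of one double bond.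

Compound 4 `CC(=O)OC[C@H]1O[C@@H](n2cc(CN3C(=O)/C(=C/c4ccc(N(C)C)cc4)c4ccccc43)nn2)[C@H](OC(C)=O)[C@@H](OC(C)=O)[C@@H]1OC(C)=O` is the next compound. It differs from compound 3 in one place: dimethylamino in place of hydrogen on an aromatic carbon. Going by the values given here, no measured step in this set involves adding or removing a group of this kind; the one step available concerns only double-bond geometry and is within the scatter, so it offers no guide to a substituent change. The expectation therefore leans on compound 3 itself, with a modest allowance for either direction, and the step expected from compound 3 to compound 4 is a 1.5-fold lower number from compound 3 to compound 4 (0.18 log units; within the scatter). Compound 4 is estimated to give 15000 nM, with a plausible range from 4000 nM to 60000 nM.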

Compound 4, half-maximal inhibitory concentration: 11200 nM
Compound 4: middle estimate off by 1.3-fold (0.13 log units), on the high side, and the stated range covers the measured number.
By their numbers in this assay, from the lowest: compound 4; then compounds 3 and 2 (each within the scatter of the next); then compound 1.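

For the compounds shown here, until now the only step between neighbours concerned double-bond geometry and stayed within the scatter, whereas the change from phenyl to 4-(dimethylamino)phenyl gives the first step in this set that goes beyond it: a 2.0-fold lower number from compound 3 to compound 4 (0.31 log units; beyond the scatter). This shows that in this assay the number can respond to a group placed on this six-membered aromatic ring, para to a large group, and that here it moves towards a stronger inhibitor, though only a little past the scatter. The data given include no measured property of the dimethylamino group that bears on this step, so the step stands without an explanation.

A single substituent at a single place cannot show whether the nitrogen, the two methyl groups or simply the presence of any group accounts for the step, and a plain amino group, a chlorine or a carboxylic acid at the same place would help to separate these possibilities. Going by these compounds alone, it also remains open whether the same change would give a similar step on the other double-bond geometry, the one drawn in compound 2.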